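Aryl replacement on the hydrazone carbon of the shared core

The source may report more compounds than this note shows. Statements on the series, on what has been measured and on what is new or still open speak of the compounds shown alone.

Measured compounds in a functional assay on HT-29 cells (Homo sapiens) for cytotoxicity, read by MTT assay, with a stated time of 72 h; on this read-out lower numbers stand for stronger inhibition and higher numbers for weaker inhibition:
compound 1 `CN(C)CCn1cnnc1-c1cc(Oc2ccc(NC(=O)N/N=C/c3c[nH]c4ccccc34)cc2F)ccn1` gives 1300 nM.
compound 2 `COc1ccc(OC)c(/C=N/NC(=O)Nc2ccc(Oc3ccnc(-c4nncn4CCN(C)C)c3)c(F)c2)c1` gives 2070 nM.
compound 3 `CN(C)CCn1cnnc1-c1cc(Oc2ccc(NC(=O)N/N=C/c3ccccc3)cc2F)ccn1` gives 1120 nM.

Compound 3 has the lowest of the three numbers, but the two steps leading to it, a 1.2-fold lower number from compound 1 to compound 3 (0.06 log units; within the scatter) and a 1.8-fold lower number from compound 2 to compound 3 (0.27 log units; within the scatter), both sit within the scatter, so no order among the three can be claimed. The three compounds differ only in the aryl group on the carbon with a double bond to nitrogen.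

Compound 4 `COc1cc(/C=N/NC(=O)Nc2ccc(Oc3ccnc(-c4nncn4CCN(C)C)c3)c(F)c2)cc(OC)c1OC` has not been measured. It differs from compound 3 in one place: 3,4,5-trimethoxyphenyl in place of phenyl on a carbon with a double bond to nitrogen.

Among the measured compounds shown here, the step that bears on this change is the one from compound 2 to compound 3, where a methoxy-bearing phenyl was exchanged for phenyl and the number moved a 1.8-fold lower number from compound 2 to compound 3 (0.27 log units; within the scatter), within the scatter. Compound 1, with a bicyclic aryl group, also stays within the scatter of compound 3 a 1.2-fold lower number from compound 1 to compound 3 (0.06 log units; within the scatter). Methoxy substitution on this phenyl therefore gave no step beyond the scatter in the one comparison available, and none is expected for compound 4 either, with at most a slight move toward a higher number.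

Compound 4 is expected to give about 1600 nM, in a range from 800 nM to 3500 nM. That estimate means a step of a 1.4-fold higher number from compound 3 to compound 4 (0.15 log units; within the scatter), within the scatter.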

Compound 4, half-maximal inhibitory concentration: 3620 nM
Beside the measured number, compound 4's estimate is 2.3-fold (0.35 log units) below it; the measured number lies above the stated range.
By their numbers in this assay, from the lowest: compounds 3, 1, 2 and 4 (each within the scatter of the next, the first and the last beyond it).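

In this assay, among the compounds shown here, 3,4,5-trimethoxyphenyl on this carbon gives the only steps beyond the scatter, with a 3.2-fold higher number from compound 3 to compound 4 (0.51 log units; beyond the scatter) against phenyl and a 2.8-fold higher number from compound 1 to compound 4 (0.44 log units; beyond the scatter) against 1H-indol-3-yl. Compound 2 limits this pattern: with its 2,5-dimethoxyphenyl group, it stays within the scatter of compound 3, and the comparison with the other methoxy-bearing aryl group shows a 1.7-fold higher number from compound 2 to compound 4 (0.24 log units; within the scatter), so methoxy substitution as such does not separate the compounds, and only the two ends of the series, compound 3 and compound 4, stand clearly apart. No measurement shown here explains the move toward a higher number with 3,4,5-trimethoxyphenyl.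

The compounds shown leave open whether the step follows the number of methoxy groups or their arrangement on the phenyl ring, a question that a phenyl carrying a single methoxy group, or other trimethoxyphenyl arrangements, would bear on. They also leave open how this carbon responds to aryl groups carrying something other than methoxy, such as a hydroxy group, a carboxylic acid or a primary amine.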